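Replacing a Trifluoromethylphenyl Urea with a Fluorophenyl Urea

The source may hold more compounds than are shown below. What is called first, only, known or untested is meant among the compounds shown, and "the series" means these compounds.

The measured compounds are:
compound 1 `COc1cc(NC(C)CCCNC(=O)NNC(=O)Nc2cc(C(F)(F)F)cc(C(F)(F)F)c2)c2ncccc2c1` with 16000 nM
compound 2 `COc1cc(NC(C)CCCNC(=O)Nc2ccc(C(F)(F)F)cc2)c2ncccc2c1` with 22000 nM
compound 3 `COc1cc(NC(C)CCCNC(=O)NNC(=O)Nc2cccc(C(F)(F)F)c2)c2ncccc2c1` with 21000 nM
Compound 4 `COc1cc(NC(C)CCCNC(=O)Nc2cccc(F)c2)c2ncccc2c1` has not yet been measured.

In a functional assay on SW-620 cells (Homo sapiens) for inhibition, read by MTT assay, with a stated time of 72 h (on this read-out higher numbers stand for weaker inhibition and lower numbers for stronger inhibition), the three measured compounds sit close together: compound 2 lies within the scatter of both compound 1 and compound 3, so none of them can be separated from the others on this read-out. Compound 4 differs from compound 2 in one place: 3-fluorophenyl in place of 4-(trifluoromethyl)phenyl on an amide-type nitrogen. Among the compounds with values here, the only measured step that bears on this change is a 1.3-fold higher number from compound 1 to compound 3 (0.12 log units; within the scatter), where removing a trifluoromethyl group from the aromatic ring left the number within the scatter. Nothing in the data suggests that altering the fluorine substitution on the terminal aryl ring moves this assay beyond its scatter. Compound 4 is therefore expected to stay near compound 2, with an estimated step of no change at the digits printed from compound 2 to compound 4 (within the scatter). Compound 4 is estimated at 22000 nM, with an expected range from 9000 nM to 55000 nM.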

Compound 4, half-maximal inhibitory concentration: 27000 nM
The estimate for compound 4 lay 1.2-fold (0.09 log units) below the measured number, and the stated range covers the measured number.
By their numbers in this assay, from the lowest: compounds 1, 3, 2 and 4 (each within the scatter of the next).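

In this assay, within the data shown here, this is the first change made directly on the aryl group of the simple urea, and it gave a 1.2-fold higher number from compound 2 to compound 4 (0.09 log units; within the scatter) with no separation between the two compounds. The earlier step, from compound 1 to compound 3, only removed one trifluoromethyl group from a ring that kept another, whereas here 3-fluorophenyl replaces 4-(trifluoromethyl)phenyl, so both the substituent and its ring position differ, and the read-out still does not respond beyond its scatter. Nothing available accounts for this result and it stands as an observation only.

Since both features changed at once, the compounds shown cannot separate the role of the substituent from that of its ring position, which a 4-fluorophenyl group would address. From the compounds shown here alone, how an amine or a carboxylic acid on this ring would read in this assay also remains open.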